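The source may hold more compounds than are shown below. What is called first, only, known or untested is meant among the compounds shown, and "the series" means these compounds.

Compound 1 `CSCc1ncnc2c1ncn2[C@@H]1O[C@H](CO)[C@@H](O)[C@H]1O`: > 100000 nM
Compound 2 `CC(=O)N(Cc1ccccc1)Cc1ncnc2c1ncn2[C@@H]1O[C@H](CO)[C@@H](O)[C@H]1O`: > 100000 nM
Compound 3 `O=C(O)CNCc1ncnc2c1ncn2[C@@H]1O[C@H](CO)[C@@H](O)[C@H]1O`: > 100000 nM

These results come from a functional assay on Huh-7 cells (Homo sapiens) for cytotoxicity, read by MTT assay, with a stated time of 3 days (a higher number here means that more compound is tolerated, a lower number that less compound is tolerated), and none of them is an exact number. Compound 3 gives > 100000 nM, which is a limit of the assay. It shares this position with the other two compounds: the limit of > 100000 nM in this assay, at which 3 of the 3 values shown sit.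

Compound 4 `O=C(O)CSCc1ncnc2c1ncn2[C@@H]1O[C@H](CO)[C@@H](O)[C@H]1O` keeps the shared core and changes one group: (carboxymethyl)sulfanyl in place of (carboxymethyl)amino on a saturated chain carbon bound to an aromatic carbon. Here (carboxymethyl)sulfanyl takes the place of (carboxymethyl)amino on a saturated chain carbon bound to an aromatic carbon.

Within the data shown here, the one measured step at this place is a step that the two limits leave unreadable from compound 1 to compound 3, so it gives no size to carry over. Compound 1 already carries a sulfanyl group at this place and gives > 100000 nM, again a limit. With compound 3 also at > 100000 nM, no change beyond the scatter is expected, and the estimated step is a number no higher from compound 3 to compound 4 (the limit leaves the size open). Compound 4 is estimated at 100000 nM, with an expected range from 50000 nM to 200000 nM, and will most likely be reported only as a limit.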

Compound 4, half-maximal cytotoxic concentration: > 100000 nM
Compound 4: only a limit was reported; the forecaster's own chance of this, stated with the estimate: 90%; the middle value lies on the limit itself.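

The steps from compound 3 to compound 4 and from compound 1 to compound 4 cannot be read, because both ends of each step are limits: the limit of > 100000 nM in this assay, at which 4 of the 4 values shown sit.

The compounds shown leave open what concentration of any of them would harm the cells in this assay, and whether the change of group alters it.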